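Fluorine on the Phenyl Ring and Tolerated Concentration

The source may hold more compounds than are shown below. What is called first, only, known or untested is meant among the compounds shown, and "the series" means these compounds.

Of the compounds shown here, three sharing one core have been tested in an ADME assay on L02 cells (Homo sapiens) for cytotoxicity, read by MTT assay, with a stated time of 24 h; a lower number here means that less compound is tolerated, a higher number that more compound is tolerated. Compound 1 `Cc1ccc(-n2cc(-c3ccccc3NS(=O)(=O)c3c[nH]c(=O)[nH]c3=O)nn2)cc1` gives > 100000 nM in this assay, a limit of the assay rather than a number. Compound 2 `O=c1[nH]cc(S(=O)(=O)Nc2ccccc2-c2cn(-c3ccccc3Cl)nn2)c(=O)[nH]1`, with 2-chlorophenyl in place of 4-methylphenyl on an aromatic nitrogen, gives 22800 nM in this assay; this is an at least 4.3-fold lower number from compound 1 to compound 2 (0.64 log units; beyond the scatter). Compound 3 `O=c1[nH]cc(S(=O)(=O)Nc2cccc(-c3cn(-c4ccccc4)nn3)c2)c(=O)[nH]1` gives > 100000 nM in this assay, again only a limit and not a number. Compound 3 thus stands at the limit of > 100000 nM in this assay, at which 2 of the 3 values shown sit, and no number places it in order with compound 2.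

Compound 4 `O=c1[nH]cc(S(=O)(=O)Nc2cccc(-c3cn(-c4ccc(F)cc4)nn3)c2)c(=O)[nH]1` differs from compound 3 by fluoro in place of hydrogen on an aromatic carbon of a six-membered aromatic ring of carbon only, para to a large group, so that phenyl becomes 4-fluorophenyl. For the measured compounds named here, the only measured step, an at least 4.3-fold lower number from compound 1 to compound 2 (0.64 log units; beyond the scatter), concerns a different substitution on the aromatic nitrogen's ring and offers no close guide to a single fluoro. Compound 4 is therefore expected to show a number no higher from compound 3 to compound 4 (the limit leaves the size open) in this assay, nothing beyond the scatter. The estimated value of compound 4 in this assay is 100000 nM, within 35000 nM to 300000 nM, and it may well again be reported only as a limit.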

Compound 4, half-maximal cytotoxic concentration: "not toxic" (no number reported)
Compound 4: no number reported; no gap can be computed for the estimate.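

For the compounds shown here, no step from compound 3 to compound 4 can be read: compound 4 is reported only as "not toxic", without a number, and compound 3 has only a limit of the assay. The compounds shown leave open whether 4-fluorophenyl in place of phenyl changes the tolerated concentration at all, and in which direction.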